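Moving the methyl around a pyridyl ring in triazole antagonists

A few compounds are considered here, and "the series" means these few. Any claim that something is new, unique, unknown or untested is made for them only; others in the source may bear on it.

Measured so far:
compound 1 `Cc1ccccc1-c1cc(F)cc(-n2nnc(-c3ccccn3)n2)c1` 120 nM
compound 2 `Fc1cc(-c2ccccn2)cc(-n2nnc(-c3ccccn3)n2)c1` 39 nM
compound 3 `Cc1ncccc1-c1cc(F)cc(-n2nnc(-c3ccccn3)n2)c1` 41 nM

Of the compounds shown here, three sharing one core have been tested in a functional assay for antagonist activity at metabotropic glutamate receptor 5 (Rattus norvegicus); on this read-out higher numbers stand for weaker inhibition and lower numbers for stronger inhibition. Compound 1 gives 120 nM, compound 2 gives 39 nM and compound 3 gives 41 nM. Compound 3 therefore stands second highest of the three numbers, but its gap to compound 2 is within the scatter a 1.1-fold higher number from compound 2 to compound 3 (0.02 log units; within the scatter), while its distance from compound 1 is a clear step of a 2.9-fold lower number from compound 1 to compound 3 (0.47 log units; beyond the scatter), matching the step of a 3.1-fold lower number from compound 1 to compound 2 (0.49 log units; beyond the scatter).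

Compound 4 `Cc1ccc(-c2cc(F)cc(-n3nnc(-c4ccccn4)n3)c2)cn1` is the next member. It differs from compound 3 in one place 6-methylpyridin-3-yl in place of 2-methylpyridin-3-yl on an aromatic carbon: the two compounds have the same atoms joined differently. Among the measured compounds shown here, no measured step isolates this kind of change; the steps that bear on it only show that exchanging 2-methylphenyl for either pyridyl group lowered the number by a modest amount, and that the two pyridyl groups gave numbers within the scatter of each other. Compound 4 is therefore expected to stay close to compound 3, with no step beyond the scatter a 1.1-fold higher number from compound 3 to compound 4 (0.04 log units; within the scatter). The estimate for compound 4 in this assay is 45 nM, within a range from 15 nM to 130 nM.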

Compound 4, half-maximal inhibitory concentration: 57 nM
Compound 4: the middle estimate sits 1.3-fold (0.10 log units) below what was measured; the measured number falls inside the stated range.
By their numbers in this assay, from the lowest: compounds 2, 3 and 4 (each within the scatter of the next); then compound 1.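

Exchanging 2-methylpyridin-3-yl for 6-methylpyridin-3-yl on the aromatic carbon of the shared core gives the first direct test of rearranging the same atoms within this pyridyl group, and in this assay the change stays within the scatter (a 1.4-fold higher number from compound 3 to compound 4 (0.14 log units; within the scatter)). Compound 4 also cannot be separated from the unmethylated pyridin-2-yl compound (a 1.5-fold higher number from compound 2 to compound 4 (0.16 log units; within the scatter)), so the three pyridyl groups shown give numbers that this read-out does not distinguish, despite their different arrangements. The advantage over 2-methylphenyl, previously seen with two pyridyl groups, holds for this third one as well, although the step remains modest (a 2.1-fold lower number from compound 1 to compound 4 (0.32 log units; beyond the scatter)), and all three pyridyl compounds fit this pattern with no exception among the compounds shown.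

No available evidence explains why this rearrangement leaves the number so little changed. On these data alone, it remains open whether the tolerance extends beyond a methyl group, for instance to an ethyl chain, a methoxy group or an amine on the pyridine ring, and whether any such group would separate itself from compounds 2, 3 and 4 by more than the scatter.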